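The source may hold more compounds than are shown below. What is called first, only, known or untested is meant among the compounds shown, and "the series" means these compounds.

Measured compounds:
compound 1 `Clc1ccc(C(/C=C/c2ccccc2)=N\Nc2nncc3ccccc23)cc1`, 2.3 nM
compound 2 `Cc1cc(NS(=O)(=O)c2ccc(Nc3nncc4ccccc34)cc2)no1`, 23 nM

Compound 1 `Clc1ccc(C(/C=C/c2ccccc2)=N\Nc2nncc3ccccc23)cc1` and compound 2 `Cc1cc(NS(=O)(=O)c2ccc(Nc3nncc4ccccc34)cc2)no1` were both tested in a functional assay on HT-29 cells (Homo sapiens) for antiproliferative activity, read by sulforhodamine B assay, with a stated time of 72 h; a lower number here means a stronger inhibitor, a higher number a weaker inhibitor. Compound 1 gives 2.3 nM, while compound 2 gives 23 nM; compound 2 therefore holds the higher of the two numbers, and the gap between it and compound 1 lies beyond the usual scatter. For the measured compounds named here, the two compounds share only part of their framework, so no single-point step between them can be drawn.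

Compound 3 `O=S(=O)(Nc1ccccn1)c1ccc(Nc2nncc3ccccc23)cc1` has not yet been measured. It differs from compound 2 in one place:

pyridin-2-yl in place of 5-methyl-1,2-oxazol-3-yl on a sulfonamide nitrogen

Going by the values given here, since no comparable step between measured compounds exists here, the expectation for compound 3 rests on compound 2 alone. A small step, within or close to the scatter and with no clear direction, is expected as a 1.3-fold higher number from compound 2 to compound 3 (0.12 log units; within the scatter). Compound 3 is thus estimated at 30 nM, with a range from 8 nM to 120 nM.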

Compound 3, half-maximal inhibitory concentration: 38 nM
Beside the measured number, compound 3's estimate is 1.3-fold (0.10 log units) below it, within the range that was stated.
By their numbers in this assay, from the lowest: compound 1; then compounds 2 and 3 (each within the scatter of the next).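

For the compounds shown here, on a sulfonamide nitrogen, pyridin-2-yl in place of 5-methyl-1,2-oxazol-3-yl gives a 1.7-fold higher number from compound 2 to compound 3 (0.22 log units; within the scatter) in this assay, which is the first comparison that differs in only one place. The result shows that, at this position, a six-membered aromatic ring with one hetero atom and a five-membered aromatic ring with two hetero atoms cannot be told apart in this assay, so the exact identity of this ring is not decisive for these two groups. Nothing measured alongside these numbers accounts for this result.

On these data alone, it remains open whether a plain methyl group or an unsubstituted phenyl ring on the sulfonamide nitrogen would read alike. As far as these compounds go, the effect of an amine or a carboxylic acid on the pyridin-2-yl ring also remains unknown.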